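Swapping the aryl hydrazide for a butyl amide

A few compounds are considered here, and "the series" means these few. Any claim that something is new, unique, unknown or untested is made for them only; others in the source may bear on it.

Compound 3 `O=C(Nc1sc2c(c1C(=O)NNc1ccc(Br)cc1)CCCCC2)NS(=O)(=O)c1ccccc1` has no number of its own in a functional assay on cells (Leukemia cell, Homo sapiens) for inhibition, with a stated time of 48 h; on this read-out lower numbers stand for stronger inhibition of growth and higher numbers for weaker inhibition of growth; its value of > 100000 nM is a limit of the assay. Compound 1 `O=C(Nc1sc2c(c1C(=O)NNc1ccccc1)CCCCC2)NS(=O)(=O)c1ccccc1` gives 18600 nM in this assay. Compound 2 `CN1CCN(C(=O)c2c(NC(=O)NS(=O)(=O)c3ccccc3)sc3c2CCCCC3)CC1` reports > 100000 nM, likewise a limit. Thus the limit of > 100000 nM in this assay, at which 2 of the 3 values shown sit, marks where two of the three measured compounds stand. Compound 4 `CCCCNC(=O)c1c(NC(=O)NS(=O)(=O)c2ccccc2)sc2c1CCCCC2` carries butyl in place of (4-bromophenyl)amino on an amide-type nitrogen. Two measured steps speak to this change. Within the data shown here, the exchange of the carbonyl substituent gave an at least 5.3-fold higher number from compound 1 to compound 2 (0.73 log units; beyond the scatter), the only other swap at this carbonyl in the set, and it removed the activity seen in compound 1. The bromo substitution gave an at least 5.3-fold higher number from compound 1 to compound 3 (0.73 log units; beyond the scatter). Between the two limits the step reads a step that the two limits leave unreadable from compound 2 to compound 3, so nothing can be taken from it. Among the measured compounds shown here, the single active compound here keeps the anilinoamino group; its replacement by a basic amine in compound 2 left no measurable inhibition, and a plain butyl chain departs from that group at least as far. Compound 4 is therefore expected to stay at or near the limit, an estimated step that the limit leaves unreadable from compound 3 to compound 4 with little chance of a readable number. The estimate for compound 4 is 120000 nM, with a range from 30000 nM to 500000 nM.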

Compound 4, concentration for 50% growth inhibition: > 100000 nM
Compound 4 gave a limit, no number; the forecaster's own chance of this, stated with the estimate: 65%; the middle value is on the limit's open side.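

In this assay, butyl in place of anilino on an amide-type nitrogen gives an at least 5.3-fold higher number from compound 1 to compound 4 (0.73 log units; beyond the scatter), so the loss of a readable number is not confined to the 4-methylpiperazin-1-yl group of compound 2 or the bromo group of compound 3. It also appears with an open chain that carries no aromatic ring. The steps to compound 4 from compound 2 and compound 3 cannot be read, as both ends of each are limits, so nothing ranks these three compounds against one another. At this carbonyl carbon, only the anilinoamino group of compound 1 keeps a readable number, and the other three compounds end at the same limit: the limit of > 100000 nM in this assay, at which 3 of the 4 values shown sit.

From the compounds shown here alone, it remains open whether a benzylamino or a 2-phenylethylamino group, which would restore an aromatic ring on a carbon chain, would bring back a readable number. Going by these compounds, it is equally open whether a fluoro or a methoxy group in place of the bromo of compound 3 would keep the growth inhibition seen with compound 1.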